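The source may hold more compounds than are shown below. What is called first, only, known or untested is meant among the compounds shown, and "the series" means these compounds.

Compound 3 `CC#C[C@@H](Cc1nnn[nH]1)c1ccc(OCc2ccc3sc(I)c(-c4ccccc4C)c3c2)cc1` gives 28 nM in a functional assay on cells for agonist activity at Free fatty acid receptor 1 (Homo sapiens), read by FLIPR and calcium flux (on this read-out higher numbers stand for an effect only at larger amounts of compound and lower numbers for an effect already at smaller amounts), the second highest of the three numbers at hand. Compound 2 `CC#C[C@@H](Cc1nnn[nH]1)c1ccc(OCc2ccc3sc(C#N)c(-c4ccccc4C)c3c2)cc1` gives 16 nM and compound 1 `CC#C[C@@H](Cc1nnn[nH]1)c1ccc(OCc2ccc3sc(C)c(-c4ccc(OCCOC)cc4C)c3c2)cc1` gives 47 nM; all three sit within the scatter of one another, so no order among them can be drawn. For the measured compounds named here, the one measured step that varies this position, a 1.8-fold higher number from compound 2 to compound 3 (0.24 log units; within the scatter), is small. Compound 4 `CC#C[C@@H](Cc1nnn[nH]1)c1ccc(OCc2ccc3sc(C)c(-c4ccccc4C)c3c2)cc1` differs from compound 3 only in methyl in place of iodo on an aromatic carbon. Compound 1 also carries methyl at this site, though with a differently substituted aryl group, and its number lies close to that of compound 3. The exchange at this position has so far moved nothing beyond the scatter, so compound 4 is expected to change little, a 1.3-fold higher number from compound 3 to compound 4 (0.10 log units; within the scatter), and is estimated at 35 nM with a range of 15 nM to 80 nM.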

Compound 4, half-maximal effective concentration: 20 nM
Compound 4: middle estimate off by 1.8-fold (0.24 log units), on the high side; the measured number falls inside the stated range.
By their numbers in this assay, from the lowest: compounds 2, 4, 3 and 1 (each within the scatter of the next, the first and the last beyond it).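

With a 1.4-fold lower number from compound 3 to compound 4 (0.15 log units; within the scatter) and a 1.3-fold higher number from compound 2 to compound 4 (0.10 log units; within the scatter), methyl, iodo and cyano on this carbon next to the ring sulfur cannot be told apart. For the compounds shown here, the only step here beyond the scatter lies elsewhere, with hydrogen in place of 2-methoxyethoxy: a 2.4-fold lower number from compound 1 to compound 4 (0.37 log units; beyond the scatter), a modest change. No measurement at hand explains these numbers. Open, going by these compounds, is whether an amine, a carboxylic acid or a longer chain on this carbon would move the number beyond the scatter, and whether the 2-methoxyethoxy step holds with iodo or cyano there.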